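Sulfonyl Esters Against a Primary Sulfonamide on One Core

The source may hold more compounds than are shown below. What is called first, only, known or untested is meant among the compounds shown, and "the series" means these compounds.

Compound 3 `CCCCCOS(=O)(=O)c1ccc(F)c2ncc(I)cc12` carries a pentyloxy group on its sulfonyl sulfur. In an assay for inhibition of methylcytosine dioxygenase TET2 (Homo sapiens), read by mass spectrometry, with stated times of 30 min and 1 h (a lower number here means a stronger inhibitor, a higher number a weaker inhibitor), compound 3 gives only a limit, > 200000 nM. Compound 2 `CC(C)OS(=O)(=O)c1ccc(F)c2ncc(I)cc12` also gives only a limit in this assay, > 200000 nM. Compound 1 `Cc1oncc1NS(=O)(=O)c1ccc(F)c2ncc(I)cc12`, with a ring-bearing group on the sulfonyl sulfur, gives 2100 nM in this assay. The steps of an at least 95-fold higher number from compound 1 to compound 2 (1.97 log units; beyond the scatter) and an at least 95-fold higher number from compound 1 to compound 3 (1.97 log units; beyond the scatter) show how much is lost when an oxygen-linked chain replaces that group, while a step that the two limits leave unreadable from compound 2 to compound 3 cannot be read. Compound 4 `NS(=O)(=O)c1ccc(F)c2ncc(I)cc12` makes the change (amino in place of pentyloxy on a sulfonyl sulfur). Because both oxygen-linked chains sit at the limit of > 200000 nM in this assay, at which 2 of the 3 values shown sit, a nitrogen on the sulfonyl sulfur is expected to bring a large step toward stronger inhibition, an at least 33-fold lower number from compound 3 to compound 4 (1.52 log units; beyond the scatter). Compound 4 is estimated at 6000 nM, within 800 nM to 60000 nM.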

Compound 4, half-maximal inhibitory concentration: 86600 nM
For compound 4 the middle estimate is 14-fold (1.16 log units) below the measured one; measured number above the stated range.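

An amino group on the sulfonyl sulfur brings inhibition back into a measurable range, giving an at least 2.3-fold lower number from compound 3 to compound 4 (0.36 log units; beyond the scatter) and an at least 2.3-fold lower number from compound 2 to compound 4 (0.36 log units; beyond the scatter) against the two oxygen-linked chains. The picture changes on the other side, with a 41-fold higher number from compound 1 to compound 4 (1.62 log units; beyond the scatter) once the 5-methyl-1,2-oxazol-4-yl group leaves the sulfonamide nitrogen, so a nitrogen alone does not restore the inhibition of compound 1. The two gains are minimum sizes only, because compound 2 and compound 3 give limits rather than numbers: the limit of > 200000 nM in this assay, at which 2 of the 4 values shown sit.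

On these data alone, how much of the gap to compound 1 depends on a ring stays open. A methyl group or a phenyl ring on the sulfonamide nitrogen would help to separate the two.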